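Replacing Oxolan-2-yl: A Clearance Estimate for Compound 3

The source may hold more compounds than are shown below. What is called first, only, known or untested is meant among the compounds shown, and "the series" means these compounds.

Measured so far in an ADME assay on microsomes from liver (Homo sapiens) for metabolic stability; on this read-out higher numbers stand for fast clearance and lower numbers for slow clearance

- compound 1 `Nc1ncc(-c2cc([C@@H]3CCCO3)nc(N3C[C@@H]4C[C@H]3CO4)n2)nc1OC(F)F` gives 12.6 mL/min/kg
- compound 2 `Nc1ncc(-c2cc(C3CC3)nc(N3C[C@@H]4C[C@H]3CO4)c2)nc1OC(F)F` gives 15.8 mL/min/kg

Clearance describes how quickly a compound is removed, so low numbers are favourable here. Compound 1 stands level with compound 2. Their two values lie within the usual scatter of each other.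

Compound 3 `Nc1ncc(-c2cc(N3CC4CC3C4)nc(N3C[C@@H]4C[C@H]3CO4)n2)nc1OC(F)F` has not yet been measured. Compared with compound 1, it carries one change: a group of 6 heavy atoms (5 carbon, 1 nitrogen; one four-membered non-aromatic ring of carbon only, one five-membered non-aromatic ring with 1 hetero atom) in place of a group of 5 heavy atoms (4 carbon, 1 oxygen; one five-membered non-aromatic ring with 1 hetero atom), on an aromatic carbon next to the ring nitrogen. Among the compounds with values here, no measured pair here shows a change in one place, so the data give no direct guide to this step. The estimated change is small, a 1.3-fold higher number from compound 1 to compound 3 (0.13 log units; within the scatter) and is expected to stay within the scatter. For compound 3 the estimated clearance is 17 mL/min/kg with an expected range from 8 mL/min/kg to 35 mL/min/kg in this assay and this remains only an expectation until measured.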

Compound 3, clearance: 9.3 mL/min/kg
Beside the measured number, compound 3's estimate is 1.8-fold (0.26 log units) above it, within the range that was stated.
By their numbers in this assay, from the lowest: compounds 3, 1 and 2 (each within the scatter of the next).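

In this assay, within the data shown here, compounds 1 and 3 form the first pair that differs in one place, and the exchange gives a 1.4-fold lower number from compound 1 to compound 3 (0.13 log units; within the scatter). At this position, on an aromatic carbon next to the ring nitrogen, oxolan-2-yl with its defined stereocentre can therefore give way to a larger group, with a four-membered carbon ring and a five-membered ring holding a nitrogen, while the clearance stays within the usual scatter. Nothing measured here bears on what lies behind this result.

On these data alone, one exchange at one position says little about other groups there, so it remains open whether a simple dimethylamino group or a carboxylic acid would also stay within the scatter in this assay. Also open, as far as these compounds go, is whether this exchange would give a similar step on a different core.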